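Chain homologation across two hydrazone cores: cytotoxicity notes

This account rests on a few compounds, and the source may have more. Where it says the series, first, only, none or still open, it means among the compounds named here.

Measured so far in a functional assay on SGC-7901 cells (Homo sapiens) for cytotoxicity, read by MTT assay, with a stated time of 72 h; a lower number here means a stronger inhibitor, a higher number a weaker inhibitor:
compound 1 `CN(C)CCNc1nc(N/N=C/c2ccc(Cl)cc2)nc2ccccc12` gives 970 nM
compound 2 `CN(C)CCCNc1nc(N/N=C/c2ccc(Cl)cc2)nc2ccccc12` gives 1730 nM
compound 3 `CN(C)CCNc1nc(N/N=C/c2nccn2Cc2ccccc2)nc2ccccc12` gives 4300 nM

Compound 2 differs from compound 1 by (dimethylamino)methyl in place of dimethylamino on a saturated chain carbon, two bonds along the chain from a nitrogen on an aromatic ring. That change produced a 1.8-fold higher number from compound 1 to compound 2 (0.25 log units; within the scatter). Compound 3 carries a different core from compound 1; the difference between the two cores is not broken down here. In this assay compound 3 stands highest of the three, beyond the scatter against compound 1 and compound 2.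

Compound 4 `CN(C)CCCNc1nc(N/N=C/c2nccn2Cc2ccccc2)nc2ccccc12` is not yet measured. It differs from compound 3 by (dimethylamino)methyl in place of dimethylamino on a saturated chain carbon, two bonds along the chain from a nitrogen on an aromatic ring, the same change as between compound 1 and compound 2, at the same place. Within the data shown here, the expected step is a 1.7-fold higher number from compound 3 to compound 4 (0.24 log units; within the scatter), resting on a 1.8-fold higher number from compound 1 to compound 2 (0.25 log units; within the scatter) as the only measured instance of this change, and on a different core. Compound 4 is estimated at 7500 nM, with an expected range from 3200 nM to 18000 nM.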

Compound 4, half-maximal inhibitory concentration: 2130 nM
For compound 4 the middle estimate is 3.5-fold (0.55 log units) above the measured one; measured number below the stated range.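

On the core of compound 3, replacing (2-(dimethylamino)ethyl)amino with (3-(dimethylamino)propyl)amino in this assay gives a 2.0-fold lower number from compound 3 to compound 4 (0.31 log units; beyond the scatter). The step measured on the core of compound 1 therefore does not carry over to the core of compound 3: the same change on two cores in this assay, a 1.8-fold higher number (0.25 log units; within the scatter) from compound 1 to compound 2 and a 2.0-fold lower number (0.31 log units; beyond the scatter) from compound 3 to compound 4, 3.6-fold (0.56 log units) apart, beyond the scatter of two such steps

With a single pair on each core, this shows that the result of the change differs between these two cores, but it gives no rule for any further core and does not identify what in the cores sets them apart.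

The compounds shown leave open how a longer chain would behave on either core. They also leave open whether diethylamino in place of dimethylamino would show the same difference between the cores.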